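Chloro to methoxy on the fused core: cytotoxicity notes

A few compounds are considered here, and "the series" means these few. Any claim that something is new, unique, unknown or untested is made for them only; others in the source may bear on it.

Compound 1 `CCOC(=O)c1c(-c2cccc(OC)c2)[nH]c2cc(OC)ccc2c1=O`, compound 2 `CCOC(=O)c1c(-c2cccc(Cl)c2)[nH]c2cc(OC)ccc2c1=O` and compound 3 `CCOC(=O)c1c(-c2cccc(-c3ccccc3)c2)[nH]c2cc(Cl)c(Cl)cc2c1=O` have been run in an ADME assay on HEK293 cells (Homo sapiens) for cytotoxicity, read by luminescence, with a stated time of 72 h; a higher number here means that more compound is needed for the effect, a lower number that less compound is needed. In this assay compound 1 gives > 22000 nM, which is a limit of the assay and not a number. Compound 2 gives > 22000 nM, likewise a limit. Compound 3 gives > 22000 nM, again a limit. The step that the two limits leave unreadable from compound 2 to compound 1 therefore has no readable size, as both ends sit at the limit of > 22000 nM in this assay, at which 3 of the 3 values shown sit. The change from compound 2 to compound 1 is methoxy in place of chloro on an aromatic carbon. Compound 4 `CCOC(=O)c1c(-c2cccc(-c3ccccc3)c2)[nH]c2cc(OC)c(Cl)cc2c1=O` is not yet measured and differs from compound 3 by methoxy in place of chloro on an aromatic carbon. This is the same kind of change, but the place differs: in compound 3 the ring is part of a fused or bridged system of two rings and the carbon is ortho to a chloro group, meta to a fused ring and para to a fused ring, whereas in compound 2 the carbon is meta to a large group. The difference between the two cores is not broken down here. The step that the limit leaves unreadable from compound 3 to compound 4 is expected to be small because a step that the two limits leave unreadable from compound 2 to compound 1 has no readable size. Compound 4 is expected to give 30000 nM in this assay, probably again as a limit.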

Compound 4, half-maximal effective concentration: > 22000 nM
Compound 4: a limit, no number; the forecaster's own chance of this, stated with the estimate: 80%; the middle value lies beyond the limit too.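

No step can be read between compound 3 and compound 4, as both stand at a limit and not a number: the limit of > 22000 nM in this assay, at which 4 of the 4 values shown sit.

The compounds shown leave open whether methoxy in place of chloro changes the result in this assay at either place, and at what concentration any of these compounds would reach the half-maximal effect.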